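Shortening the Ether Chain in a Low-Toxicity Series

This account rests on a few compounds, and the source may have more. Where it says the series, first, only, none or still open, it means among the compounds named here.

Compound 1 `CCCCCCCCOc1nc(N)nc2c1ncn2/C=C1/CC1(CO)CO` was tested in an ADME assay on CCRF-HSB-2 cells (Homo sapiens) for cytotoxicity, with a stated time of 7 days; on this read-out lower numbers stand for higher toxicity in this test and higher numbers for lower toxicity in this test. In this assay compound 1 gives > 20000 nM, which is a limit of the assay rather than a number. Two companions share its core. Compound 2 `CCCCSc1nc(N)nc2c1ncn2/C=C1/CC1(CO)CO` carries butylsulfanyl in place of octyloxy on an aromatic carbon, and in this assay compound 2 gives 89000 nM. Compound 3 `CN(C)c1nc(N)nc2c1ncn2/C=C1/CC1(CO)CO` carries dimethylamino in place of octyloxy on an aromatic carbon. In this assay compound 3 gives > 20000 nM, again a limit. The steps a step that the limit leaves unreadable from compound 1 to compound 2, a step that the two limits leave unreadable from compound 1 to compound 3 and a step that the limit leaves unreadable from compound 2 to compound 3 cannot be sized because the limit of > 20000 nM in this assay, at which 2 of the 3 values shown sit, caps two of the three values; all that can be said is that every measured value sits in the low-toxicity region.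

Compound 4 `COCCOc1nc(N)nc2c1ncn2/C=C1/CC1(CO)CO` differs from compound 1 in one place: methoxy in place of hexyl on a saturated chain carbon, two bonds along the chain from an oxygen on an aromatic ring. Read one bond further out, octyloxy becomes 2-methoxyethoxy. Among the compounds with values here, none of the measured steps is readable, so no step size can be borrowed for this change. Since every measured compound stays in the low-toxicity region, compound 4 is expected to do the same, with an estimated value of 50000 nM in this assay, ranging from 20000 nM to 150000 nM. The step expected is a step that the limit leaves unreadable from compound 1 to compound 4, most likely reported only as a limit again.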

Compound 4, half-maximal cytotoxic concentration: > 20000 nM
Compound 4 was reported as a limit; the forecaster's own chance of this, stated with the estimate: 70%; the middle value is on the limit's open side.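

In this assay compound 4 gives > 20000 nM, which is a limit and not a number. No step to compound 4 from compound 1, compound 2 or compound 3 can be read, because of where the values sit: the limit of > 20000 nM in this assay, at which 3 of the 4 values shown sit.

The compounds shown leave open how large the true differences in toxicity among these four compounds are.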